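A few compounds are considered here, and "the series" means these few. Any claim that something is new, unique, unknown or untested is made for them only; others in the source may bear on it.

In a functional assay on HT-29 cells (Homo sapiens) for inhibition, read by MTT assay, with a stated time of 72 h (on this read-out higher numbers stand for weaker inhibition and lower numbers for stronger inhibition), compound 2 (`C=C(Br)C(=O)Nc1cccc(/C=C/C(=O)Nc2ccc(F)cc2)c1`) gives 36600 nM as the highest of three measured numbers, which makes it the weakest inhibitor so far. Compound 3 (`C=C(Br)C(=O)Nc1cccc(/C=C/C(=O)Nc2ccc(F)c(F)c2)c1`) gives 8700 nM and compound 1 (`COc1cc(NC(=O)/C=C/c2cccc(OCc3ccccc3)c2)cc(OC)c1OC`), which is built differently, gives 3600 nM on the same read-out.

The open case is compound 4 (`C=C(Br)C(=O)Nc1cccc(/C=C/C(=O)Nc2ccc(OCC)cc2)c1`), which differs from compound 2 by one swap (ethoxy in place of fluoro on an aromatic carbon): ethoxy in place of fluoro on an aromatic carbon, para to a large group. Within the data shown here, the only measured step on that ring is a 4.2-fold lower number from compound 2 to compound 3 (0.62 log units; beyond the scatter) when fluoro replaces hydrogen on an aromatic carbon, and it is modest but beyond the scatter. That is a different change, since compound 4 loses the fluoro and gains ethoxy, so it is only a rough guide to size and gives no firm direction.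

With compound 2 at 36600 nM at the top of the numbers, a modest move to a lower number is expected in this assay and not a large one. The estimated step is a 2.4-fold lower number from compound 2 to compound 4 (0.39 log units; beyond the scatter) and it remains uncertain. For compound 4 the estimated value is 15000 nM with an expected range from 5000 nM to 45000 nM for the measurement.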

Compound 4, half-maximal inhibitory concentration: 3400 nM
Compound 4: the middle estimate sits 4.4-fold (0.64 log units) above what was measured, outside the stated range (below it).
By their numbers in this assay, from the lowest: compounds 4 and 1 (each within the scatter of the next); then compound 3; then compound 2.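

In this assay, the swap at this aromatic carbon, para to a large group, gives an 11-fold lower number from compound 2 to compound 4 (1.03 log units; beyond the scatter), a large step that exceeds the modest 4.2-fold lower number from compound 2 to compound 3 (0.62 log units; beyond the scatter). The earlier compounds shown here showed only that adding a fluoro to this ring lowers the number, whereas this result shows that the fluoro can be given up at this position and replaced by the bigger ethoxy, with its 3 heavy atoms and a hydrogen-bond acceptor, for a much stronger result. Nothing measured here explains why this swap has such an effect.

A single ethoxy example cannot separate the role of the oxygen from that of the carbon chain. Methoxy, a longer butoxy chain or an amine at the same position would help to tell these apart.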